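One Inverted Stereocentre in a Small Antiproliferative Series

The source may report more compounds than this note shows. Statements on the series, on what has been measured and on what is new or still open speak of the compounds shown alone.

Measured in a functional assay on ID8 cells (Mus musculus) for antiproliferative activity; a lower number here means a stronger inhibitor, a higher number a weaker inhibitor:
- compound 1 `C[C@@H](NC(=O)OC(C)(C)C)C(=O)Nc1ccc(O)c2c(=O)cc(-c3ccccc3Cl)oc12` gives 104000 nM
- compound 2 `CC(C)C[C@@H](NC(=O)OC(C)(C)C)C(=O)Nc1ccc(O)c2c(=O)cc(-c3ccccc3Cl)oc12` gives 17000 nM
- compound 3 `CSCC[C@@H](NC(=O)OC(C)(C)C)C(=O)Nc1ccc(O)c2c(=O)cc(-c3ccccc3Cl)oc12` gives 13000 nM

The three compounds share a core and differ in the group on a saturated chain carbon. Compound 2 sits at the low end of these numbers alongside compound 3, and the two cannot be told apart, as the step of a 1.3-fold lower number from compound 2 to compound 3 (0.12 log units; within the scatter) shows. Compound 1 stands clearly higher than both.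

The next compound to be tested is compound 4 `CC(C)C[C@H](NC(=O)OC(C)(C)C)C(=O)Nc1ccc(O)c2c(=O)cc(-c3ccccc3Cl)oc12`. Its relation to compound 2 is simple: the two compounds have the same atoms and bonds and differ only in configuration as drawn: 1 of 1 stereo elements differ; a stereocentre at a saturated chain carbon is drawn R in compound 2 and S in compound 4. No group is exchanged, and only the configuration is drawn differently.

Within the data shown here, none of the measured steps changes configuration alone, so the data offer no direct precedent and no direction. The nearest evidence comes from replacing the chain group, which gave a 6.1-fold lower number from compound 1 to compound 2 (0.79 log units; beyond the scatter) and an 8.0-fold lower number from compound 1 to compound 3 (0.90 log units; beyond the scatter). These steps show that changes at this carbon can register in this assay, so the range is kept wide, but they do not predict the effect of inversion.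

The expectation therefore stays close to compound 2 at 17000 nM, with no step beyond the scatter anticipated. The expected step is a 1.1-fold higher number from compound 2 to compound 4 (0.02 log units; within the scatter). The estimate for compound 4 is 18000 nM, with an expected range from 6000 nM to 55000 nM.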

Compound 4, half-maximal inhibitory concentration: 5100 nM
The estimate for compound 4 lay 3.5-fold (0.55 log units) above the measured number; measured number below the stated range.
By their numbers in this assay, from the lowest: compound 4; then compounds 3 and 2 (each within the scatter of the next); then compound 1.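

In this assay, the configuration at this saturated chain carbon registers on its own, with no group exchanged, as a 3.3-fold lower number from compound 2 to compound 4 (0.52 log units; beyond the scatter) shows. That step can be assigned to the stereocentre alone, because nothing else separates the pair: the fact that compounds 2 and 4 differ only in the configuration as drawn. The earlier compounds had shown only that exchanging the group on this carbon can shift the number, in a 6.1-fold lower number from compound 1 to compound 2 (0.79 log units; beyond the scatter) and an 8.0-fold lower number from compound 1 to compound 3 (0.90 log units; beyond the scatter); the new result adds that, with the same group in place, the drawn S form gives the lower number and the drawn R form the higher one, so the position responds to how its group is arranged as well as to which group it carries.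

This holds for a single pair, so the compounds shown leave open whether inverting the same carbon in compound 1 or compound 3 would move the number in the same direction or by a similar amount. They also leave open how this carbon would respond in either configuration to a group of another kind, such as a carboxylic acid, an amine or a longer chain.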